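The compounds below may be only part of what the source reports. "The series", "measured", "known", "first", "only" and "open" are said of these compounds alone.

Three compounds of this series share one core and differ only in the aryl group carried on an aromatic nitrogen. Compound 1 `N#CC1=C(N)Oc2c(c3nc4ccccc4nc3c3ccccc23)C12C(=O)N(Cc1cnnn1-c1ccc(N)cc1)c1ccccc12` reaches only the limit of an ADME assay on HUVEC cells (Homo sapiens) for antiproliferative activity, read by MTT assay, with a stated time of 48 h (a higher number here means a weaker inhibitor, a lower number a stronger inhibitor), reported as > 50000 nM. Compound 2 `Cc1ccc(-n2nncc2CN2C(=O)C3(C(C#N)=C(N)Oc4c3c3nc5ccccc5nc3c3ccccc43)c3ccccc32)c(C)c1` likewise comes back in this assay as a limit, > 50000 nM. The step that the two limits leave unreadable from compound 1 to compound 2 therefore cannot be read, as both ends are limits. Compound 3 `CCc1ccccc1-n1nncc1CN1C(=O)C2(C(C#N)=C(N)Oc3c(N)cc4nc5ccccc5nc4c32)c2ccccc21` stands in the same place: in this assay compound 3 gives a limit, > 50000 nM, so nothing more than that is known of where it lies.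

Compound 4 `Cc1cc(C)cc(-n2nncc2CN2C(=O)C3(C(C#N)=C(N)Oc4c(N)cc5nc6ccccc6nc5c43)c3ccccc32)c1` is not yet measured. Its change from compound 3 is 3,5-dimethylphenyl in place of 2-ethylphenyl on an aromatic nitrogen. For the measured compounds named here, the one measured step that touches this position, the aryl group on the aromatic nitrogen, is unreadable, and every value shown sits at the same point, as the limit of > 50000 nM in this assay, at which 3 of the 3 values shown sit, records. On that basis compound 4 is expected to return the same limit, with an estimate of 50000 nM and a range from 20000 nM to 100000 nM. The expected step of a number no higher from compound 3 to compound 4 (the limit leaves the size open) is thus no change beyond the scatter.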

Compound 4, half-maximal inhibitory concentration: > 50000 nM
Compound 4: no number, only a limit; the forecaster's own chance of this, stated with the estimate: 85%; the middle value lies on the limit itself.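

Compound 3 and compound 4 both return only a limit, so the step between them cannot be read. The compounds shown leave open how any aryl group on the aromatic nitrogen affects the result in this assay, since all of them stop at one point: the limit of > 50000 nM in this assay, at which 4 of the 4 values shown sit.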